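Nitro to fluoro exchange in a cytotoxicity series

This account rests on a few compounds, and the source may have more. Where it says the series, first, only, none or still open, it means among the compounds named here.

Compound 1, `COc1cc(N(C)C(=O)N(C)c2ccc(F)cc2)cc(OC)c1OC`: in a functional assay on ONS-76 cells (Homo sapiens) for cytotoxicity, read by MTT assay, with a stated time of 72 h (on this read-out higher numbers stand for weaker inhibition and lower numbers for stronger inhibition), compound 1 gives >= 125000 nM. That value is a limit of the assay.
Compound 2, `COc1cc(N(C)C(=O)N(C)c2ccc([N+](=O)[O-])cc2)cc(OC)c1OC`: in this assay compound 2 gives >= 125000 nM. That value is a limit of the assay.
Compound 3, `COc1cc(NC(=O)c2ccc([N+](=O)[O-])cc2)cc(OC)c1OC`: in this assay compound 3 gives >= 125000 nM. That value is a limit of the assay.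

All three measured compounds sit at the same limit, so none of them shows a measurable half-maximal inhibitory concentration in this assay. Compound 2 and compound 1 differ in one place, (fluoro in place of nitro on an aromatic carbon), and the step between them, a step that the two limits leave unreadable from compound 2 to compound 1, cannot be read in size because the limit of >= 125000 nM in this assay, at which 3 of the 3 values shown sit, holds both ends of it. Compound 3 differs from compound 2 in more than one place, and the difference between the two cores is not broken down here.

Compound 4, `COc1cc(NC(=O)c2ccc(F)cc2)cc(OC)c1OC`, is not yet measured. It differs from compound 3 by fluoro in place of nitro on an aromatic carbon, the same change as that from compound 2 to compound 1, at the same kind of place. Since that earlier change left both compounds at the limit, the expectation for compound 4 in this assay is that it stays at the limit as well, and the step that the limit leaves unreadable from compound 3 to compound 4 is estimated to be unreadable in the same way. Compound 4 is therefore expected to give about 150000 nM in this assay, with a likely range from 60000 nM to 400000 nM, most probably reported only as a limit.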

Compound 4, half-maximal inhibitory concentration: >= 125000 nM
Compound 4 gave a limit, no number; the forecaster's own chance of this, stated with the estimate: 85%; the middle value does not contradict the limit.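

In this assay compound 4 gives >= 125000 nM, which is a limit of the assay and not a number. No new step can be read between compound 3 and compound 4, as both ends of the exchange of nitro for fluoro are held by the same limit: the limit of >= 125000 nM in this assay, at which 4 of the 4 values shown sit. The compounds shown leave open whether either this exchange or the difference between the cores alters the half-maximal inhibitory concentration at all.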